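The source may report more compounds than this note shows. Statements on the series, on what has been measured and on what is new or still open speak of the compounds shown alone.

Working notes on the series.

Compound 1 `CC(C)c1ccc(-c2nc(SCc3cn(CC(=O)NC(=O)Nc4ccccn4)nn3)nc(Nc3cccc(Cl)c3)c2C#N)cc1`, compound 2 `Cc1ccc(Nc2nc(SCc3cn(CC(=O)NC(=O)Nc4ccccn4)nn3)nc(-c3ccc(C(C)C)cc3)c2C#N)cc1` and compound 3 `Cc1ccc(Nc2nc(SCc3cn(CC(=O)NC(=O)Nc4ccccn4)nn3)nc(-c3ccc(C)cc3)c2C#N)cc1` share one core and differ only in the group on the nitrogen on the aromatic ring and in the group on the aromatic carbon. In a functional assay on MGC-803 cells (Homo sapiens) for inhibition, read by MTT assay, with a stated time of 72 h (a lower number here means a stronger inhibitor, a higher number a weaker inhibitor), compound 2 gives 3360 nM. In this assay compound 3 gives 9890 nM. Compound 1 gives > 64000 nM in this assay, which is a limit of the assay and not a number, as shown by the limit of > 64000 nM in this assay, at which 1 of the 3 values shown sits.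

From compound 2 to compound 1 the change is 3-chlorophenyl in place of 4-methylphenyl on a nitrogen on an aromatic ring and the step is an at least 19-fold higher number from compound 2 to compound 1 (1.27 log units; beyond the scatter). From compound 2 to compound 3 the change is methyl in place of isopropyl on an aromatic carbon and the step is a 2.9-fold higher number from compound 2 to compound 3 (0.47 log units; beyond the scatter).

Compound 4 `Cc1ccc(-c2nc(SCc3cn(CC(=O)NC(=O)Nc4ccccn4)nn3)nc(Nc3cccc(Cl)c3)c2C#N)cc1` has not yet been measured in this assay. It differs from compound 3 by 3-chlorophenyl in place of 4-methylphenyl on a nitrogen on an aromatic ring, the same change as from compound 2 to compound 1, since the two places read the same; the pairs differ in their cores by the change just given, isopropyl against methyl. Because the earlier step was an at least 19-fold higher number from compound 2 to compound 1 (1.27 log units; beyond the scatter), the step from compound 3 to compound 4 is expected to be of like size, about a 12-fold higher number from compound 3 to compound 4 (1.08 log units; beyond the scatter). The estimate for compound 4 is 120000 nM, expected to lie between 30000 nM and 400000 nM.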

Compound 4, half-maximal inhibitory concentration: 7890 nM
The estimate for compound 4 lay 15-fold (1.18 log units) above the measured number; the measured number lies below the stated range.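

In this assay, 3-chlorophenyl in place of 4-methylphenyl on the nitrogen does not carry from one core to the other: with methyl on the aromatic carbon the change gives a 1.3-fold lower number from compound 3 to compound 4 (0.10 log units; within the scatter), whereas with isopropyl there the same change gives a much larger step in the opposite direction: the same change on two cores in this assay, an at least 19-fold higher number (1.27 log units; beyond the scatter) from compound 2 to compound 1 and a 1.3-fold lower number (0.10 log units; within the scatter) from compound 3 to compound 4, at least 23-fold (1.37 log units) apart, beyond the scatter of two such steps Read along the other place, methyl in place of isopropyl gives an at least 8.1-fold lower number from compound 1 to compound 4 (0.90 log units; beyond the scatter) with 3-chlorophenyl on the nitrogen, and this also differs from the step with 4-methylphenyl there: the same change on two cores in this assay, a 2.9-fold higher number (0.47 log units; beyond the scatter) from compound 2 to compound 3 and an at least 8.1-fold lower number (0.90 log units; beyond the scatter) from compound 1 to compound 4, at least 23-fold (1.37 log units) apart, beyond the scatter of two such steps Compound 1 gives > 64000 nM, which is a limit of the assay and not a number, so the full size of both gaps stays unread, and these four compounds show neither a cause for the dependence between the two places nor a rule for other cores.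

The compounds shown leave open whether the dependence is specific to isopropyl or would also appear with ethyl or tert-butyl on the aromatic carbon. Going by these compounds, it is equally open whether other groups on the nitrogen, such as unsubstituted phenyl or 4-chlorophenyl, would behave like 3-chlorophenyl or like 4-methylphenyl on each core.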